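A few compounds are considered here, and "the series" means these few. Any claim that something is new, unique, unknown or untested is made for them only; others in the source may bear on it.

Three measured compounds share one core and differ only in the ring that sits on a carbon with a double bond to nitrogen. Compound 1 `O=C(CSc1nnc(-c2ccncc2)o1)N/N=C/c1ccc(F)cc1` in a functional assay on BGC-823 cells (Homo sapiens) for cytotoxicity, read by MTT assay, with a stated time of 48 h (a higher number here means a weaker inhibitor, a lower number a stronger inhibitor), gives 17800 nM. Compound 2 `O=C(CSc1nnc(-c2ccncc2)o1)N/N=C/c1cccc(F)c1` gives 27500 nM, and compound 3 `O=C(CSc1nnc(-c2ccncc2)o1)N/N=C/c1ccccc1F` gives 24000 nM. Among these three numbers compound 3 has the second highest, yet the gaps are small: a 1.1-fold lower number from compound 2 to compound 3 (0.06 log units; within the scatter) and a 1.3-fold higher number from compound 1 to compound 3 (0.13 log units; within the scatter), while the remaining pair shows a 1.5-fold higher number from compound 1 to compound 2 (0.19 log units; within the scatter), so none of the three can be told apart in this assay. Compound 4 `COc1cc(/C=N/NC(=O)CSc2nnc(-c3ccncc3)o2)ccc1O` carries a change of a different kind: 4-hydroxy-3-methoxyphenyl in place of 2-fluorophenyl on a carbon with a double bond to nitrogen. Among the compounds with values here, no measured step exchanges a fluorine-bearing ring for one bearing a hydroxy and a methoxy group, so the three small steps offer only the general observation that this part of the molecule has so far been altered without any shift beyond the scatter. On that basis the expected step of a 1.2-fold lower number from compound 3 to compound 4 (0.08 log units; within the scatter) is none beyond the scatter in this assay. Compound 4 is therefore estimated at 20000 nM in this assay, with a range from 7000 nM to 60000 nM.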

Compound 4, half-maximal inhibitory concentration: 4320 nM
Beside the measured number, compound 4's estimate is 4.6-fold (0.67 log units) above it, and the stated range ends above it.
By their numbers in this assay, from the lowest: compound 4; then compounds 1, 3 and 2 (each within the scatter of the next).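

The three fluorophenyl rings could not be told apart in this assay, but this position does respond to a larger change of ring, with a 5.6-fold lower number from compound 3 to compound 4 (0.74 log units; beyond the scatter) and a 6.4-fold lower number from compound 2 to compound 4 (0.80 log units; beyond the scatter) and a 4.1-fold lower number from compound 1 to compound 4 (0.61 log units; beyond the scatter) all arising when 4-hydroxy-3-methoxyphenyl takes the place of a fluorophenyl ring. The group on the carbon with a double bond to nitrogen can therefore alter the result, and compound 4 has the lowest number of the four, with all three of its steps beyond the scatter. No supporting measurement bears on what lies behind this shift.

As far as these compounds go, the hydroxy and methoxy groups enter together here, so the share of each in the shift remains open. Also open, from the compounds shown here alone, is how the number would respond to an amine or a carboxylic acid on this ring.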